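The compounds below may be only part of what the source reports. "The series", "measured", "known", "first", "only" and "open" are said of these compounds alone.

Of the compounds shown here, three built on one shared core have been tested in an assay on Sf9 cells for inhibition of histone deacetylase 11 (Homo sapiens), read by fluorescence, tested at 0.5 uM; a lower number here means less inhibition, a higher number more inhibition at the concentration tested (going by the name of the read-out). Compound 1 `O=C(NO)c1ccc(-c2cn([C@@H]3C[C@H](C(=O)O)N(CCCc4ccccc4)C3)nn2)cc1` gives < 10%, which is a limit of the assay rather than a number. Compound 2 `O=C(NO)c1cccc(-c2cn([C@H]3C[C@@H](CO)N(CCCc4ccccc4)C3)nn2)c1` gives < 10%, again a limit of the assay and not a measured number. Compound 3 `O=C(NO)c1cccc(-c2cn([C@@H]3C[C@@H](C(=O)O)N(CCCc4ccccc4)C3)nn2)c1` gives < 10%, also a limit of the assay. So compound 2 stands exactly where the other measured compounds stand, as the limit of < 10% in this assay, at which 3 of the 3 values shown sit, shows, with nothing in this set separating it from compound 1 or compound 3.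

Compound 4 `O=C(NO)c1ccc(-c2cn([C@H]3C[C@@H](CO)N(CCCc4ccccc4)C3)nn2)cc1` has not yet been tested in this assay. It differs from compound 2 in one place: 4-(hydroxycarbamoyl)phenyl in place of 3-(hydroxycarbamoyl)phenyl on an aromatic carbon. Among the measured compounds shown here, no pair of measured compounds differs in only one place, so no measured step shows what this change does on its own. The nearest hint comes from compound 1, which already carries the 4-(hydroxycarbamoyl)phenyl group and gives < 10%, a limit of the assay.

The expected step is therefore a step that the limit leaves unreadable from compound 2 to compound 4, nothing beyond the usual scatter. Compound 4 is estimated at 5%, within a range from 0% to 15%, and the assay is expected most likely to report only its limit again.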

Compound 4, a percentage reported as inhibition, at one concentration (the size of the read-out at that concentration, not a potency): < 10%
Compound 4 gave a limit, no number; the forecaster's own chance of this, stated with the estimate: 80%; the middle value is on the limit's open side.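

Among the compounds shown here, compound 2 and compound 4 both end at a limit of this assay rather than at a number, so swapping 3-(hydroxycarbamoyl)phenyl for 4-(hydroxycarbamoyl)phenyl gives no step that can be read: the limit of < 10% in this assay, at which 4 of the 4 values shown sit. The compounds shown leave open whether any change to the shared core can raise inhibition to a measurable number.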